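The source may report more compounds than this note shows. Statements on the series, on what has been measured and on what is new or still open speak of the compounds shown alone.

Compound 1 `O=C(O)c1ccc(CN2C(=O)S/C(=C\c3ccccc3)C2=O)cc1`: 72000 nM
Compound 2 `Cn1cccc1/C=C1\SC(=O)N(Cc2ccc(C(=O)O)cc2)C1=O`: 90000 nM

Both compounds were measured in a functional assay on HeLa cells (Homo sapiens) for cytotoxicity, read by MTT assay, with a stated time of 24 h; a higher number here means a weaker inhibitor, a lower number a stronger inhibitor. Compound 2 is one of only two numbers shown here, and it sits alongside compound 1: the step of a 1.3-fold higher number from compound 1 to compound 2 (0.10 log units; within the scatter) lies within the scatter, so the two cannot be told apart on these data.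

Compound 3 `Cc1ccc(/C=C2\SC(=O)N(Cc3ccc(C(=O)O)cc3)C2=O)cc1` has not yet been measured. It differs from compound 2 as follows: 4-methylphenyl in place of 1-methyl-1H-pyrrol-2-yl on a double-bonded chain carbon bound to a double-bonded ring carbon. Among the compounds with values here, the only measured step that bears on this position is a 1.3-fold higher number from compound 1 to compound 2 (0.10 log units; within the scatter), in which a phenyl at this place was exchanged for 1-methyl-1H-pyrrol-2-yl without a change beyond the scatter. Compound 3 returns a six-membered carbon-only ring to the same place, so no step beyond the scatter is expected in this assay from compound 2 to compound 3, in either direction, and the expected step is a 1.2-fold lower number from compound 2 to compound 3 (0.08 log units; within the scatter).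

Compound 3 is therefore estimated at 75000 nM in this assay, with a range of 30000 nM to 180000 nM.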

Compound 3, half-maximal inhibitory concentration: 68000 nM
Compound 3: middle estimate off by 1.1-fold (0.04 log units), on the high side, and the stated range covers the measured number.
By their numbers in this assay, from the lowest: compounds 3, 1 and 2 (each within the scatter of the next).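

In this assay the 4-methylphenyl in place of 1-methyl-1H-pyrrol-2-yl gives a 1.3-fold lower number from compound 2 to compound 3 (0.12 log units; within the scatter), so a second six-membered aromatic ring of carbon only now stands against the five-membered one at this place, again without a change beyond the scatter. Within the data shown here, the methyl in place of hydrogen on an aromatic carbon, a change the earlier compounds did not cover, gives a 1.1-fold lower number from compound 1 to compound 3 (0.02 log units; within the scatter), so phenyl and 4-methylphenyl cannot be told apart here either. No supporting measurement bears on this result.

On these data alone, whether an amine or a fluorine atom on that aromatic ring, or an ethyl chain in place of the methyl, would give a step beyond the scatter remains open. The rest of the core is the same in all three compounds, so they say nothing about changes elsewhere.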